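Adding a second methoxy to compound 2

The source may hold more compounds than are shown below. What is called first, only, known or untested is meant among the compounds shown, and "the series" means these compounds.

Compound 1 `COc1ccc(-c2nc(C)c(C(=O)CSc3nc(N)c(C#N)c(-c4ccccc4)n3)s2)cc1` gives 8540 nM
Compound 2 `COc1cccc(-c2nc(SCC(=O)c3sc(-c4ccccc4)nc3C)[nH]c(=O)c2C#N)c1` gives 59700 nM

In a functional assay on U-87MG ATCC cells for antiproliferative activity against U-87 MG (Homo sapiens), read by MTT assay, with a stated time of 48 h (a higher number here means a weaker inhibitor, a lower number a stronger inhibitor), compound 2 has the higher of the two numbers, so it is the weaker inhibitor of this pair, and its gap to compound 1 lies beyond the usual scatter. Compound 3 `COc1ccc(-c2nc(SCC(=O)c3sc(-c4ccccc4)nc3C)[nH]c(=O)c2C#N)cc1OC` has not been measured yet. It differs from compound 2 by methoxy in place of hydrogen on an aromatic carbon in one place: methoxy in place of hydrogen on an aromatic carbon, ortho to a methoxy group, so 3-methoxyphenyl becomes 3,4-dimethoxyphenyl. Among the measured compounds shown here, no measured pair shows this single change, so any forecast is loose. For the measured compounds named here, compound 2 at 59700 nM holds the top of the two known numbers, and compound 1 at 8540 nM is the only lower one. The expected step of a 1.5-fold lower number from compound 2 to compound 3 (0.17 log units; within the scatter) in this assay is small and toward a lower number. Compound 3 is estimated at 40000 nM (expected range 12000 nM to 100000 nM).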

Compound 3, half-maximal inhibitory concentration: 15300 nM
For compound 3 the middle estimate is 2.6-fold (0.42 log units) above the measured one; low and high end bracket the measured number.
By their numbers in this assay, from the lowest: compounds 1 and 3 (each within the scatter of the next); then compound 2.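

In this assay, among the compounds shown here, the place para to a large group and ortho to a methoxy group is now tested directly for the first time: turning 3-methoxyphenyl into 3,4-dimethoxyphenyl gives a 3.9-fold lower number from compound 2 to compound 3 (0.59 log units; beyond the scatter). The step is modest but lies beyond the usual scatter, so this aromatic carbon takes an added methoxy without any loss of activity, and the change moves the number toward a stronger inhibitor. No measurement at hand explains why the number falls.

The compounds shown leave open whether a hydroxyl, a fluorine or an ethoxy on this carbon would move the number the same way, and whether any other group here would do as well as methoxy. As far as these compounds go, with a single pair, it also remains open whether the same change would give a similar step on a different core.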